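From Acetoxy to Chloro on the Shared Side Chain

The source may hold more compounds than are shown below. What is called first, only, known or untested is meant among the compounds shown, and "the series" means these compounds.

For the measured compounds named here, compound 2 `COc1nc(C)c(CCOC(C)=O)c(OC)n1` is the only compound here with an actual number: in a functional assay on MCF7 cells (Homo sapiens) for antiproliferative activity, read by MTT assay, with a stated time of 24 h (on this read-out higher numbers stand for weaker inhibition and lower numbers for stronger inhibition), compound 2 gives 65000 nM. Compound 1 `COc1nc(C)c(CCO)c(OC)n1` differs from it only by a hydrogen in place of the acetyl on the oxygen, and in this assay compound 1 gives > 100000 nM, which is a limit of the assay rather than a number. Going by the values given here, the one measured step, an at least 1.5-fold lower number from compound 1 to compound 2 (0.18 log units; that floor lies within the scatter), is therefore only a floor and lies within the usual scatter, as the limit of > 100000 nM in this assay, at which 1 of the 2 values shown sits, shows. Compound 3 `COc1nc(C)c(CCCl)c(OC)n1` carries the change (chloro in place of acetoxy on a saturated chain carbon, two bonds along the chain from an aromatic carbon). Among the compounds with values here, no measured step involves a chloro group, so the only guide is that swapping the alcohol for its acetate changed little. The expected step is a 1.2-fold lower number from compound 2 to compound 3 (0.07 log units; within the scatter), estimated to stay within scatter. Compound 3 is thus expected to give about 55000 nM, in a range from 18000 nM to 160000 nM.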

Compound 3, half-maximal inhibitory concentration: > 100000 nM
Compound 3: a limit, no number; the forecaster's own chance of this, stated with the estimate: 35%; middle value at least 1.8-fold (0.25 log units) away from the limit.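

Chloro in place of acetoxy on this chain gives an at least 1.5-fold higher number from compound 2 to compound 3 (0.18 log units; that floor lies within the scatter) in this assay. Going by these compounds, this is only a floor, so the true size of the step stays unknown, but the swap to a single chlorine atom, with no hydrogen-bond acceptors, yields no actual number at this position. The step between compound 1 and compound 3 cannot be read, since both values are limits, and compound 2, the acetoxy compound, remains the only one with a real number: the limit of > 100000 nM in this assay, at which 2 of the 3 values shown sit.

On these data alone, how far past that limit compound 1 and compound 3 lie stays open. So does whether another group on this chain, such as an amine, a carboxylic acid or a longer chain, would give a step from compound 2 that stands clear of the scatter in this assay.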